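From 4-chlorophenyl to 3-methoxyphenyl on a shared core

A few compounds are considered here, and "the series" means these few. Any claim that something is new, unique, unknown or untested is made for them only; others in the source may bear on it.

Compound 1 `COc1ccc(C2=NN(C(=O)c3cccnc3)C(c3cn(C)c4ccc(Br)cc34)C2)cc1`: 1190 nM
Compound 2 `COc1ccc2c(c1)c(C1CC(c3ccccc3)=NN1C(=O)c1cccnc1)cn2C`: > 10000 nM
Compound 3 `COc1ccc2c(c1)c(C1CC(c3ccc(Cl)cc3)=NN1C(=O)c1ccc(OC)nc1)cn2C`: 3390 nM

All three values come from a single read-out (a functional assay on A549 cells (Homo sapiens) for inhibition, read by MTT assay, with a stated time of 48 h; on this read-out higher numbers stand for weaker inhibition of growth and lower numbers for stronger inhibition of growth). The entry for compound 2 (> 10000 nM) is a limit of the assay and not a number, and it is the only such entry in the set (the limit of > 10000 nM in this assay, at which 1 of the 3 values shown sits). Of the two true numbers, compound 3 (3390 nM) holds the higher, so it inhibits growth more weakly than compound 1 (1190 nM), a gap beyond the usual scatter.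

Compound 4 `COc1cccc(C2=NN(C(=O)c3ccc(OC)nc3)C(c3cn(C)c4ccc(OC)cc34)C2)c1` has not yet been measured. It carries 3-methoxyphenyl in place of 4-chlorophenyl on a carbon with a double bond to nitrogen. Going by the values given here, no two measured compounds differ in one place alone, so the data give no direct measure of such a change. Starting from compound 3 (3390 nM), a small move toward weaker inhibition of growth is expected, of a size not clearly beyond the usual scatter. The estimated change (a 1.8-fold higher number from compound 3 to compound 4 (0.25 log units; within the scatter)) is expected to be modest. For compound 4 the estimated value is 6000 nM with an expected range (2000 nM to 18000 nM).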

Compound 4, concentration for 50% growth inhibition: 470 nM
Beside the measured number, compound 4's estimate is 13-fold (1.11 log units) above it; measured number below the stated range.
By their numbers in this assay, from the lowest: compound 4; then compound 1; then compound 3. At a limit, above all of these: compound 2.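

In this assay the replacement of 4-chlorophenyl by 3-methoxyphenyl gives a 7.2-fold lower number from compound 3 to compound 4 (0.86 log units; beyond the scatter) and moves the result toward stronger inhibition of growth. Going by these compounds alone, this is the first pair in the set that differs in one place alone, so it gives the first direct reading of any single change on the shared core. It shows that the group on the carbon with a double bond to nitrogen, two ring bonds from the ring atom that bears a (6-methoxypyridin-3-yl)carbonyl group, can by itself shift the read-out beyond the usual scatter while the rest of the molecule stays the same.

Within the data shown here, the single pair leaves open whether the shift follows the departure of the chlorine, the arrival of the methoxy group, or the place that group holds on the phenyl ring, as the change alters all of these at once. It also leaves open how this carbon would respond to an amine, or to a longer chain such as ethoxy, on the phenyl ring. Nothing at hand gives a measured reason for the size of this step.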